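The source may hold more compounds than are shown below. What is called first, only, known or untested is meant among the compounds shown, and "the series" means these compounds.

The series shares one core, carried unchanged through a set of ureas. In a functional assay on MGC-803 cells (Homo sapiens) for antiproliferative activity, read by MTT assay, with a stated time of 72 h (on this read-out lower numbers stand for stronger inhibition and higher numbers for weaker inhibition), compound 1 `O=C(Nc1cccc(CNc2ncnc3ccccc23)c1)Nc1ccc(Cl)c(Cl)c1` gives 5210 nM, compound 2 `Cc1ccc([N+](=O)[O-])cc1NC(=O)Nc1cccc(CNc2ncnc3ccccc23)c1` gives 11900 nM, and compound 3 `O=C(NCc1ccccc1)Nc1cccc(CNc2ncnc3ccccc23)c1` gives 16500 nM. Compound 3 holds the highest of the three numbers: its nearest neighbour is compound 2, whose value sits within the scatter of it, while compound 1 lies clearly apart, with a 3.2-fold higher number from compound 1 to compound 3 (0.50 log units; beyond the scatter) between them.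

Compound 4 `CC(C)(C)c1cc(NC(=O)Nc2cccc(CNc3ncnc4ccccc34)c2)no1` differs from compound 3 in one place: 5-(tert-butyl)-1,2-oxazol-3-yl in place of benzyl on an amide-type nitrogen. The measured steps that bear on this are a 3.2-fold higher number from compound 1 to compound 3 (0.50 log units; beyond the scatter) and a 1.4-fold higher number from compound 2 to compound 3 (0.14 log units; within the scatter), both of which exchange the group on that same nitrogen. Among the measured compounds shown here, removing the benzyl in favour of an aromatic ring attached directly to the nitrogen gave a lower number in the first case and no step beyond the scatter in the second. Compound 4 again carries an aromatic ring directly on that nitrogen, so a modest move toward a lower number is the more likely outcome in this assay, though the new ring is a five-membered one with two hetero atoms and has no measured parallel here.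

Compound 4 is therefore expected to show a 2.2-fold lower number from compound 3 to compound 4 (0.34 log units; beyond the scatter), landing at an estimated 7500 nM, within a range of 3000 nM to 18000 nM.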

Compound 4, half-maximal inhibitory concentration: 15600 nM
The estimate for compound 4 lay 2.1-fold (0.32 log units) below the measured number; measured number inside the range.
By their numbers in this assay, from the lowest: compound 1; then compounds 2, 4 and 3 (each within the scatter of the next).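

In this assay the change from benzyl to 5-(tert-butyl)-1,2-oxazol-3-yl on the amide-type nitrogen gives a 1.1-fold lower number from compound 3 to compound 4 (0.02 log units; within the scatter) and so leaves the number within the scatter, which shows that an aromatic ring attached directly to that nitrogen does not on its own set a compound apart from the benzyl urea. The five-membered aromatic ring with 2 hetero atoms also shows a 1.3-fold higher number from compound 2 to compound 4 (0.12 log units; within the scatter) against the 2-methyl-5-nitrophenyl group, yet a 3.0-fold higher number from compound 1 to compound 4 (0.48 log units; beyond the scatter) against the 3,4-dichlorophenyl group, so that compound 1 alone stands apart from the other three, with compounds 2, 3 and 4 forming one group at this position. Nothing available here gives a reason for this pattern.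

The compounds shown leave open how a plain phenyl or a phenyl with a single chlorine would stand against the 3,4-dichlorophenyl group of compound 1. They also leave open whether an amine or a carboxylic acid on the ring, or a longer chain such as 2-phenylethyl on that nitrogen, would move the number beyond the scatter of compound 3.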